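Working notes on solubility across compounds 1 to 3

The source may report more compounds than this note shows. Statements on the series, on what has been measured and on what is new or still open speak of the compounds shown alone.

Two members of the series have been measured in a physicochemical assay for solubility, tested at 272 nM; on this read-out lower numbers stand for lower solubility and higher numbers for higher solubility. Compound 1 `CCCCCCCCCCCCCCCCOCC(COP(=O)(O)OP(=O)(O)OC[C@H]1OC(n2ccc(N)nc2=O)[C@@H](O)[C@@H]1O)OC(=O)CCCCCCCCCCCCCCC` gives 130000 nM. Compound 2 `CCCCCCCCCCCCCCOCC(COP(=O)(O)OP(=O)(O)OC[C@H]1OC(n2ccc(N)nc2=O)[C@@H](O)[C@@H]1O)OC(=O)CCCCCCCCCCCCC` is reported only as a limit of the assay, > 121000000 nM. Where compound 2 stands is thus known only through (the limit of > 121000000 nM in this assay, at which 1 of the 2 values shown sits), and no step between the two measured compounds is counted, their values lying far apart.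

Compound 3 `CCCCCCCCCCCCCCCC(=O)OC(COCCCCCCCCCCCCCC)COP(=O)(O)OP(=O)(O)OC[C@H]1OC(n2ccc(N)nc2=O)[C@@H](O)[C@@H]1O` is not yet measured. Against compound 2 it differs by ethyl in place of hydrogen on a saturated chain carbon, ten or more bonds along the chain from a carbonyl carbon. On the numbers shown, compound 2 sits at the limit while compound 1 lies well beneath it. For the step from compound 2 to compound 3 in this assay a downward move beyond the usual scatter is expected, of about an at least 24-fold lower number from compound 2 to compound 3 (1.38 log units; beyond the scatter). Compound 3 is accordingly estimated at 5000000 nM, with a range from 300000 nM to 121000000 nM, the estimate resting only on compound 1 and compound 2.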

Compound 3, solubility: > 43000000 nM
Compound 3: no number, only a limit (the forecaster's own chance of this, stated with the estimate: 30%); at least 8.6-fold (0.93 log units) between middle value and limit.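

In this assay compound 3 is reported only as a limit, > 43000000 nM. This gives the series its first readable step: hydrogen in place of ethyl on a saturated chain carbon comes with an at least 330-fold higher number from compound 1 to compound 3 (2.51 log units; beyond the scatter), a large change beyond the scatter. The step that joins the other two compounds cannot be read, since each of them is known only through a limit: the limit of > 43000000 nM in this assay, at which 1 of the 3 values shown sits.

As far as these compounds go, how far the true values of compound 2 and compound 3 lie past their limits remains open, and so does whether ethyl in place of hydrogen moves the number between them. Also open, from the compounds shown here alone, is how an amine or a carboxylic acid on this saturated chain carbon would read in this assay.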